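The source may report more compounds than this note shows. Statements on the series, on what has been measured and on what is new or still open speak of the compounds shown alone.

Measured so far:
- Compound 1, `CN1CCN(CCNCc2cn(-c3ccc(F)cc3F)nc2C2CCCCC2)CC1`, gives > 20000 nM in an ADME assay on Huh-7 cells (Homo sapiens) for cytotoxicity (on this read-out higher numbers stand for lower toxicity in this test and lower numbers for higher toxicity in this test), a limit of the assay rather than a number.
- Compound 2, `Cc1ccccc1-c1nn(-c2ccc(F)cc2F)cc1CNCCCCO`, gives > 20000 nM in this assay, again a limit, not a number.
- Compound 3, `Cc1ccccc1-c1nn(-c2ccc(OC(F)(F)F)cc2)cc1CNCCN1CCN(C)CC1`, gives 17000 nM in this assay.

Compound 2 therefore stands at the limit of > 20000 nM in this assay, at which 2 of the 3 values shown sit, so its toxicity is only bounded, not pinned down. Compound 4, `Cc1ccccc1-c1nn(-c2ccc(F)cc2F)cc1CNCCCN1CCN(C)CC1`, arises from compound 2 by one change: 4-methylpiperazin-1-yl in place of hydroxymethyl on a saturated chain carbon, three bonds along the chain from an amine nitrogen. Among the compounds with values here, no measured step covers this change, but compound 3 carries the same 4-methylpiperazin-1-yl group and gives 17000 nM. The step from compound 2 to compound 4 in this assay is expected to be none beyond the scatter, which would put compound 4 near 20000 nM, between 8000 nM and 45000 nM.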

Compound 4, half-maximal cytotoxic concentration: > 20000 nM
Compound 4 ended at the assay's limit; the forecaster's own chance of this, stated with the estimate: 50%; the middle value lies on the limit itself.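

Within the data shown here, compound 2 and compound 4 both end at a limit of this assay rather than at a number, so no step between them can be read: the limit of > 20000 nM in this assay, at which 3 of the 4 values shown sit. The compounds shown leave open whether 4-methylpiperazin-1-yl in place of hydroxymethyl changes toxicity in this test at all.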